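Benzamido replaces allyloxy on the shared core

The source may hold more compounds than are shown below. What is called first, only, known or untested is meant among the compounds shown, and "the series" means these compounds.

Compound 1 `COc1ccc(C2=C(c3cc(OC)c(OC)c(OC)c3)C(=O)C(OC(C)=O)C2)cc1OC(C)C` and compound 2 `C=CCOc1cc(C2=C(c3cc(OC)c(OC)c(OC)c3)C(=O)C(O)C2)ccc1OC` carry the same core and differ in the side groups on the outer ring and at the ring oxygen. In an ADME assay on MIA PaCa-2 cells (Homo sapiens) for cytotoxicity, read by MTT assay, with a stated time of 72 h (on this read-out higher numbers stand for weaker inhibition and lower numbers for stronger inhibition), compound 1 gives > 100 ug/mL, which is a limit of the assay and not a number. Compound 2 in this assay likewise gives > 100 ug/mL, again a limit rather than a measured number. For the measured compounds named here, the only evidence available in this assay is the limit of > 100 ug/mL in this assay, at which 2 of the 2 values shown sit. Compound 2 therefore stands at the limit, and no measured number places it relative to any other compound in this series.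

Compound 3 `COc1ccc(C2=C(c3cc(OC)c(OC)c(OC)c3)C(=O)C(O)C2)cc1NC(=O)c1ccccc1` follows from compound 2 by benzamido in place of allyloxy on an aromatic carbon, ortho to a methoxy group and meta to a large group. Going by the values given here, no measured step exists in this assay to set the size of such a change. The step that the limit leaves unreadable from compound 2 to compound 3 is expected to stay within the usual scatter, with a fair chance that only a limit is again reported. Compound 3 is expected in this assay at 110 ug/mL, within 35 ug/mL to 300 ug/mL.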

Compound 3, half-maximal inhibitory concentration: > 100 ug/mL
Compound 3: no number, only a limit (the forecaster's own chance of this, stated with the estimate: 60%); the middle value lies beyond the limit too.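

Compound 2 and compound 3 both stand at a limit and not at a number in this assay, so no step can be read between them for benzamido in place of allyloxy. The compounds shown leave open whether any change on the shared core alters this read-out, and by how much: the limit of > 100 ug/mL in this assay, at which 3 of the 3 values shown sit.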